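The source may report more compounds than this note shows. Statements on the series, on what has been measured and on what is new or still open speak of the compounds shown alone.

Measured compounds:
- compound 1, `NC1=NN(c2ccccc2)C(=O)/C1=C/Nc1ccc(S(=O)(=O)Nc2ccccn2)cc1`, with 66.9% in a functional assay on HepG2 cells (Homo sapiens) for cytotoxicity, tested at 25 uM; a lower number here means a weaker effect, a higher number a stronger effect of the compound at the concentration tested
- compound 2, `N=C1NN=C(N)/C1=C\Nc1ccc(S(=O)(=O)Nc2cnc3ccccc3n2)cc1`, with 73.2% in this assay

Compound 1 is the lower of the two numbers measured in this assay, but its gap to compound 2 is within the scatter, so the two values cannot be told apart. Compound 2 carries the quinoxalin-2-yl group on its sulfonamide nitrogen, yet it also differs from compound 1 in its core, so the two values say nothing clean about that group on its own.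

Compound 3, `NC1=NN(c2ccccc2)C(=O)/C1=C/Nc1ccc(S(=O)(=O)Nc2cnc3ccccc3n2)cc1`, keeps the core of compound 1 and changes only one place: quinoxalin-2-yl in place of pyridin-2-yl on a sulfonamide nitrogen. For the measured compounds named here, compound 2 is the only measured compound with this group, and it shows a value close to that of compound 1.

Going by the values given here, no measured pair isolates this change. The step from compound 1 to compound 3 is expected to be small, in either direction, and not beyond the scatter. On that basis, compound 3 is expected to give about 70% in this assay, within a range of 55% to 85%, which means an expected step of a number 3.1 percentage points higher from compound 1 to compound 3 (within the scatter).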

Compound 3, a percentage reported as activity, at one concentration (the size of the read-out at that concentration, not a potency): 76.2%
Beside the measured number, compound 3's estimate is 6.2 percentage points below it; the measured number falls inside the stated range.
By their numbers in this assay, from the lowest: compounds 1, 2 and 3 (each within the scatter of the next).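

In this assay, putting quinoxalin-2-yl in place of pyridin-2-yl on a sulfonamide nitrogen, with the rest of the molecule held the same, gives a number 9.3 percentage points higher from compound 1 to compound 3 (within the scatter) and so the two compounds cannot be told apart. For the compounds shown here, this is the first reading of this change on its own, since the earlier comparison also carried a difference in the core and could not separate the two effects. At this position, then, a group with a second aromatic ring and more heavy atoms leaves the read-out indistinguishable from that of the smaller pyridin-2-yl group, and no other measurement is available to explain this result.

The compounds shown cover only two aromatic groups on this nitrogen, so it remains open whether the read-out would hold with a very different group there, such as a plain methyl group or a chain ending in a carboxylic acid. The read-out also comes from a single concentration, which leaves open whether a real difference between these compounds in the strength of their effect at that concentration lies hidden within the scatter.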